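The source may report more compounds than this note shows. Statements on the series, on what has been measured and on what is new or still open speak of the compounds shown alone.

Measured so far:
compound 1 `C=CCOc1cc(F)cc(C(=O)NNS(=O)(=O)c2ccccc2F)c1` — 138 uL/min
compound 2 `Cc1cc(-n2nccn2)cc(C(=O)NNS(=O)(=O)c2ccccc2)c1F` — 28 uL/min
compound 3 `Cc1cc(-c2ncccn2)cc(C(=O)NNS(=O)(=O)c2ccccc2)c1F` — 11 uL/min

All numbers come from an ADME assay on microsomes from liver (Homo sapiens) for metabolic stability, read by HPLC, using NADPH, with a stated time of 60 min, tested at 1 uM, in the presence of a further agent that is not named here; on this read-out lower numbers stand for slow clearance and higher numbers for fast clearance. Compound 3 gives the lowest of the three numbers; its nearest neighbour is compound 2, its furthest compound 1. For the measured compounds named here, compound 1 gives 138 uL/min, whereas compound 3 gives 11 uL/min; these two differ in several places, so no single step is drawn between them.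

Compound 4 `Cc1cc(-c2ccccn2)cc(C(=O)NNS(=O)(=O)c2ccccc2)c1F` has not yet been measured in this assay. Its change from compound 3 is pyridin-2-yl in place of pyrimidin-2-yl on an aromatic carbon.

Going by the values given here, one measured step bears on it, since it also exchanges the group on that aromatic carbon for another: a 2.5-fold lower number from compound 2 to compound 3 (0.41 log units; beyond the scatter), a modest step beyond the scatter. Pyridin-2-yl itself has not been measured in this assay, and nothing among the three compounds tells how it compares with pyrimidin-2-yl. Among the compounds with values here, the one exchange of this kind that is known moved the number by a modest amount, so a step of comparable size or smaller in this assay is expected, direction uncertain, with a slight lean toward a higher number than compound 3.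

Compound 4 is therefore expected to give 18 uL/min, within 7 uL/min to 45 uL/min, which as a step means an expected 1.6-fold higher number from compound 3 to compound 4 (0.21 log units; within the scatter).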

Compound 4, intrinsic clearance in a liver preparation (reported as CLH), per the amount of preparation that the assay uses: 27 uL/min
Estimate against measurement, compound 4: 1.5-fold (0.18 log units) below; measured number inside the range.
By their numbers in this assay, from the lowest: compound 3; then compounds 4 and 2 (each within the scatter of the next); then compound 1.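

In this assay, the position para to the fluoro group now carries three aromatic rings, and pyrimidin-2-yl stands apart from the other two: replacing it with pyridin-2-yl, which has one hetero atom in the ring instead of two, gives a 2.5-fold higher number from compound 3 to compound 4 (0.39 log units; beyond the scatter). The exchange of 2H-1,2,3-triazol-2-yl for pyridin-2-yl gives a 1.0-fold lower number from compound 2 to compound 4 (0.02 log units; within the scatter), so these two groups cannot be told apart here, while pyrimidin-2-yl is separated from both. The exchange of 2H-1,2,3-triazol-2-yl for pyrimidin-2-yl gives a 2.5-fold lower number from compound 2 to compound 3 (0.41 log units; beyond the scatter). No measurement offered with these compounds accounts for this separation.

Still open, going by these compounds, is how pyrimidin-2-yl compares at this aromatic carbon with groups of another kind, such as morpholine, a simple amine or a carboxylic acid. Also open, on these data alone, is whether its separation from pyridin-2-yl persists on a different shared core, for example with a fluoro group on the phenyl ring of the sulfonyl end or with a longer chain in place of the methyl group.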